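A Methoxy in Place of a Methyl in Compound 4

The source may hold more compounds than are shown below. What is called first, only, known or untested is meant among the compounds shown, and "the series" means these compounds.

In a physicochemical assay for solubility, in phosphate buffer, measured as kinetic solubility, at pH 7.4 (a higher number here means a more soluble compound, a lower number a less soluble compound), compound 1 `Cc1oc(-c2c(Br)cccc2Br)nc1CN1CCC(C(=O)NCCCN2C[C@H](C)C[C@H](C)C2)CC1` gives 62.4 ug/mL and compound 2 `Cc1oc(-c2c(Cl)cccc2C(F)(F)F)nc1CN1CCC(C(=O)NCCCN2C[C@H](C)C[C@H](C)C2)CC1` gives 65.1 ug/mL. Compound 3 `COc1cccc(C)c1-c1nc(CN2CCC(C(=O)NCCCN3C[C@H](C)C[C@H](C)C3)CC2)c(C)o1` reads > 73 ug/mL, and this is a limit, not a number. Compound 4 `COc1cccc(OC)c1-c1nc(CN2CCC(C(=O)NCCCN3C[C@H](C)C[C@H](C)C3)CC2)c(C)o1` differs from compound 3 by methoxy in place of methyl on an aromatic carbon, giving 2,6-dimethoxyphenyl. Among the compounds with values here, three measured steps bear on this change, all among related phenyl groups: a 1.0-fold higher number from compound 1 to compound 2 (0.02 log units; within the scatter), an at least 1.1-fold higher number from compound 1 to compound 3 (0.06 log units; that floor lies within the scatter) and an at least 1.1-fold higher number from compound 2 to compound 3 (0.04 log units; that floor lies within the scatter). None shows a change beyond the scatter, although the last two are only floors. The expected step is therefore no more than the scatter, namely an at least 1.0-fold lower number from compound 3 to compound 4 (0.00 log units; that floor lies within the scatter). For compound 4 the estimated value is 72 ug/mL, with an expected range of 50 ug/mL to 95 ug/mL.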

Compound 4, solubility: > 76 ug/mL
Compound 4 gave a limit, no number; the forecaster's own chance of this, stated with the estimate: 55%; middle value at least 1.0-fold (0.02 log units) away from the limit.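

Compound 4, with methoxy in place of methyl on the aromatic carbon, gives a limit and not a number in this assay: the limit of > 76 ug/mL in this assay, at which 1 of the 4 values shown sits. Compound 3 also gives only a limit, so the step from it to compound 4 cannot be read: the limit of > 73 ug/mL in this assay, at which 1 of the 4 values shown sits. The 2,6-dimethoxyphenyl group gives an at least 1.1-fold higher number from compound 2 to compound 4 (0.06 log units; that floor lies within the scatter) and an at least 1.2-fold higher number from compound 1 to compound 4 (0.08 log units; that floor lies within the scatter), and both floors lie within the scatter.

As far as these compounds go, how far compound 3 and compound 4 lie past their limits remains open. So does whether an amine or a carboxylic acid on this phenyl ring would bring the reading down to a measurable number.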